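Hydrazone Aryl Exchange on the Shared Core

This account rests on a few compounds, and the source may have more. Where it says the series, first, only, none or still open, it means among the compounds named here.

Compound 1 `Cn1c(=O)c(=O)n(C2CCCC2)c2nc(N/N=C/c3ccc(O)cc3)ncc21` sits at a limit of > 100000 nM in a functional assay on PC-3 cells (Homo sapiens) for antiproliferative activity, read by MTT assay; on this read-out lower numbers stand for stronger inhibition and higher numbers for weaker inhibition.
Compound 2 `Cn1c(=O)c(=O)n(C2CCCC2)c2nc(N/N=C/c3ccc(O)c(F)c3)ncc21` gives 85200 nM in this assay.

For the measured compounds named here, compound 2 holds the only number in the set; the other value is a limit (the limit of > 100000 nM in this assay, at which 1 of the 2 values shown sits). Going by the values given here, the one measured step, an at least 1.1-fold lower number from compound 1 to compound 2 (0.06 log units; that floor lies within the scatter), stays within the scatter. Compound 3 `Cn1c(=O)c(=O)n(C2CCCC2)c2nc(N/N=C/c3ccco3)ncc21` brings (furan-2-yl in place of 3-fluoro-4-hydroxyphenyl on a carbon with a double bond to nitrogen). Among the compounds with values here, no measured step exchanges the whole aromatic group, so the fluoro step gives little guidance; a step beyond the scatter in this assay is not expected in either direction. Compound 3 is estimated at 90000 nM, between 30000 nM and 300000 nM, which means an expected step of a 1.1-fold higher number from compound 2 to compound 3 (0.02 log units; within the scatter).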

Compound 3, half-maximal inhibitory concentration: 72200 nM
Estimate against measurement, compound 3: 1.2-fold (0.10 log units) above; measured number inside the range.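

In this assay, furan-2-yl in place of 3-fluoro-4-hydroxyphenyl on a carbon with a double bond to nitrogen gives a 1.2-fold lower number from compound 2 to compound 3 (0.07 log units; within the scatter), so even exchanging the whole aromatic group, including loss of the hydrogen-bond donor, leaves the read-out within the scatter. Furan-2-yl in place of 4-hydroxyphenyl at the same place gives an at least 1.3-fold lower number from compound 1 to compound 3 (0.14 log units; that floor lies within the scatter). That step is only a floor, as compound 1 stands at a limit: the limit of > 100000 nM in this assay, at which 1 of the 3 values shown sits.

Still open, as far as these compounds go, is whether any group at this place moves the number beyond the scatter, for example a pyridine ring or a phenyl ring carrying an amine or a carboxylic acid.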